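The source may report more compounds than this note shows. Statements on the series, on what has been measured and on what is new or still open speak of the compounds shown alone.

The account follows compound 2 `CC(C)[C@H](C(=O)Nc1ccccc1)c1ccc(Cl)cc1` toward compound 4 `CC(C)[C@H](C(=O)NC1=NC(=O)CS1)c1ccc(Cl)cc1` in a functional assay on CHO cells for agonist activity at Free fatty acid receptor 2 (Homo sapiens), read by cAMP accumulation; on this read-out higher numbers stand for larger maximal responses and lower numbers for smaller maximal responses. Compound 2 is known only as a limit of the assay: in this assay compound 2 gives < 30%. The same holds for the two other measured compounds. Compound 1 `CC(C)C(C(N)=O)c1ccc(Cl)cc1` gives < 30% in this assay, a limit. Compound 3 `CC(C)C(C(=O)Nc1nnn[nH]1)c1ccc(Cl)cc1` gives < 30% in this assay, likewise a limit. Among the measured compounds shown here, the one step that changes a single place, a step that the two limits leave unreadable from compound 1 to compound 3, is therefore unreadable, and the limit of < 30% in this assay, at which 3 of the 3 values shown sit, is all the measured set shows. Compound 4 differs from compound 2 by a group of 6 heavy atoms (3 carbon, 1 nitrogen, 1 oxygen, 1 sulfur; one five-membered non-aromatic ring with 2 hetero atoms) in place of a group of 6 heavy atoms (6 carbon; one six-membered aromatic ring of carbon only), on an amide-type nitrogen. For the measured compounds named here, no measured step bears on this change; the one step on the same amide-type nitrogen is unreadable. With every measured value at the limit, compound 4 is expected to stay near it, and the step that the limit leaves unreadable from compound 2 to compound 4 is estimated to be small. Compound 4 is therefore estimated at 25%, within 10% to 60%.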

Compound 4, largest response reached (reported as efficacy), in percent of the reference or control that the assay uses: 96%
Beside the measured number, compound 4's estimate is 71 percentage points below it, and the stated range ends below it.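

In this assay, placing the five-membered non-aromatic ring with 2 hetero atoms on the amide-type nitrogen in place of phenyl gives a number at least 66 percentage points higher from compound 2 to compound 4 (beyond the scatter). Both groups hold 6 heavy atoms, so this step comes with no change in that count, only a change from carbon alone to carbon, nitrogen, oxygen and sulfur. It is the first readable step at this amide-type nitrogen, showing that the group carried there can lift the response clear of a limit that had left the earlier compounds unresolved: the limit of < 30% in this assay, at which 3 of the 4 values shown sit.

The compounds shown do not tell whether the ring sulfur, the ring carbonyl or the ring as a whole carries this step, nor how a carboxylic acid or a piperidine ring would read on the same nitrogen. They also leave open whether the step would hold if the chlorine on the shared core gave way to fluorine or a methyl group.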